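A Pyridine Ring Replaces the Dimethylphenyl Amide

The compounds below may be only part of what the source reports. "The series", "measured", "known", "first", "only" and "open" are said of these compounds alone.

Two compounds share a core built from a pyrazole carrying two phenyl groups and an amide. Compound 1 `O=C(Nc1cc(-c2ccccc2)nn1-c1ccccc1)c1ccccc1` carries a plain phenyl on the carbonyl carbon and in a functional assay on cells for positive allosteric modulation of metabotropic glutamate receptor 5 (Rattus norvegicus), read by calcium flux (on this read-out higher numbers stand for an effect only at larger amounts of compound and lower numbers for an effect already at smaller amounts), compound 1 gives 203 nM. Compound 2 `Cc1ccc(C(=O)Nc2cc(-c3ccccc3)nn2-c2ccccc2)cc1C` carries a 3,4-dimethylphenyl there instead, and in this assay compound 2 gives 20 nM. Going by the values given here, the one measured step, a 10-fold lower number from compound 1 to compound 2 (1.01 log units; beyond the scatter), is large and goes toward effect at smaller amounts. Among the compounds with values here, compound 2 therefore stands at the lowest of the two numbers known so far.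

Compound 3 `Cc1ccc(C(=O)Nc2cc(-c3ccccc3)nn2-c2ccccc2)cn1` changes the same position again: 6-methylpyridin-3-yl in place of 3,4-dimethylphenyl on a carbonyl carbon. Within the data shown here, only the step from compound 1 to compound 2 bears on this position, and it shows that the ring on the carbonyl carbon matters strongly. Among the measured compounds shown here, no measured pair tells what a ring nitrogen does here, and compound 3 keeps only one of the two methyl groups, so a moderate move back toward the number of compound 1 is expected. Compound 3 is estimated to give 60 nM, within 15 nM to 250 nM. That estimate means an expected step of a 3.0-fold higher number from compound 2 to compound 3 (0.48 log units; beyond the scatter).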

Compound 3, half-maximal effective concentration: 280 nM
The estimate for compound 3 lay 4.7-fold (0.67 log units) below the measured number; measured number above the stated range.
By their numbers in this assay, from the lowest: compound 2; then compounds 1 and 3 (each within the scatter of the next).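

In this assay, moving from 3,4-dimethylphenyl to 6-methylpyridin-3-yl on the carbonyl carbon gives a 14-fold higher number from compound 2 to compound 3 (1.15 log units; beyond the scatter) and so shows that the low number of compound 2 does not survive this swap. Measured against the plain phenyl, the same group gives a 1.4-fold higher number from compound 1 to compound 3 (0.14 log units; within the scatter) and so leaves no difference that can be read between these two compounds. Among the three rings shown, then, only the 3,4-dimethylphenyl group brings the low number, and a six-membered aromatic ring with a methyl group and a ring nitrogen does not keep it. No measurement shown here explains this result.

The swap changes two things at once, since a ring carbon gives way to a nitrogen and one methyl group is gone, so the compounds shown cannot say which of the two accounts for the step. From the compounds shown here alone, a phenyl ring with a single methyl group or a pyridine ring with two methyl groups would separate these two changes, and how a chlorine atom or a methoxy group would fare on this ring remains open.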